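The compounds below may be only part of what the source reports. "The series", "measured", "known", "first", "only" and "open" are said of these compounds alone.

The measured compounds:

Compound 1, `Cc1ncnc2c1c(I)cn2[C@@H]1O[C@H](CO)[C@@H](O)[C@H]1O`: 5480 nM
Compound 2, `C#Cc1cn([C@@H]2O[C@H](CO)[C@@H](O)[C@H]2O)c2ncnc(C)c12`: 5600 nM
Compound 3, `C#Cc1cn([C@@H]2O[C@H](CO)[C@@H](O)[C@H]2O)c2ncnc(NC)c12`: only a limit, > 20000 nM

All three were tested in a functional assay on CCRF-CEM cells (Homo sapiens), read by MTT assay, with a stated time of 72 h; on this read-out higher numbers stand for weaker inhibition and lower numbers for stronger inhibition. Compound 1 and compound 2 share a core and differ by iodo in place of ethynyl on an aromatic carbon; this change gives a 1.0-fold lower number from compound 2 to compound 1 (0.01 log units; within the scatter). Compound 3 differs from compound 2 by methylamino in place of methyl on an aromatic carbon, and the step is an at least 3.5-fold higher number from compound 2 to compound 3 (0.55 log units; beyond the scatter). For compound 3 the assay reports only a limit, (the limit of > 20000 nM in this assay, at which 1 of the 3 values shown sits), so no number is known for it.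

Compound 4, `CNc1ncnc2c1c(I)cn2[C@@H]1O[C@H](CO)[C@@H](O)[C@H]1O`, has not been measured. It differs from compound 3 by iodo in place of ethynyl on an aromatic carbon, the same kind of change that separates compound 2 from compound 1, made here on the core of compound 3 rather than that of compound 2; the two cores differ by methylamino in place of methyl on an aromatic carbon. Since that earlier change gave a 1.0-fold lower number from compound 2 to compound 1 (0.01 log units; within the scatter), a step within the scatter is also expected from compound 3 to compound 4, namely a step that the limit leaves unreadable from compound 3 to compound 4. Because compound 3 sits at the limit of > 20000 nM in this assay, at which 1 of the 3 values shown sits, compound 4 is expected to lie near that limit as well, estimated at 25000 nM, between 12000 nM and 60000 nM.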

Compound 4, half-maximal inhibitory concentration: > 100000 nM
Compound 4 was reported as a limit; the forecaster's own chance of this, stated with the estimate: 75%; at least 4.0-fold (0.60 log units) between middle value and limit.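

In this assay, methylamino in place of methyl on an aromatic carbon again gives a higher number on the core of compound 1, with an at least 18-fold higher number from compound 1 to compound 4 (1.26 log units; beyond the scatter). The direction therefore carries over from one core to the other, but the sizes of the two steps cannot be ranked: the same change on two cores in this assay, an at least 3.5-fold higher number (0.55 log units; beyond the scatter) from compound 2 to compound 3 and an at least 18-fold higher number (1.26 log units; beyond the scatter) from compound 1 to compound 4; the limit leaves it open whether they differ. Compound 3 and compound 4 are both reported only as limits, so the step for iodo in place of ethynyl cannot be read, and the data do not show whether that change makes as little difference on the methylamino core as on the methyl core.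

The compounds shown leave open how an unsubstituted amine or a dimethylamino group would compare with methyl and methylamino on these cores. They also leave open how a bromo or nitrile group would compare with iodo and ethynyl.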